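The source may report more compounds than this note shows. Statements on the series, on what has been measured and on what is new or still open speak of the compounds shown alone.

Compound 1 `NC(=S)N/N=C/c1cc2cccnc2s1` — > 100000 nM
Compound 2 `NC(=S)N/N=C/c1ccc2ccccc2n1` — > 100000 nM

Of the compounds shown here, two have so far been tested in a functional assay on HL-60 cells (Homo sapiens) for antiproliferative activity, read by sulforhodamine B assay, with a stated time of 72 h; on this read-out higher numbers stand for weaker inhibition and lower numbers for stronger inhibition. Compound 1 `NC(=S)N/N=C/c1cc2cccnc2s1` gives > 100000 nM, which is a limit of the assay rather than a number. Compound 2 `NC(=S)N/N=C/c1ccc2ccccc2n1` gives > 100000 nM, again only a limit. Compound 2 therefore stands at the limit of > 100000 nM in this assay, at which 2 of the 2 values shown sit, and no measured number sets it apart from its neighbour.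

Compound 3 `S=C(N/N=C/c1ccc2ccccc2n1)Nc1ccccc1` has not yet been measured in this assay . It differs from compound 2 by phenyl in place of hydrogen on an amide-type nitrogen. Among the measured compounds shown here, no measured pair shows what this change does here, so the size and direction of the step are open, and a step of any size, or none beyond the scatter, is possible. Compound 3 is expected to give about 20000 nM, within a range from 2000 nM to 100000 nM, with a real chance that the assay again reports only a limit. For compound 3 this estimate means a step of an at least 5.0-fold lower number from compound 2 to compound 3 (0.69 log units; beyond the scatter).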

Compound 3, half-maximal inhibitory concentration: 9130 nM
For compound 3 the middle estimate is 2.2-fold (0.34 log units) above the measured one; the range from low to high includes it.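

In this assay, among the compounds shown here, phenyl in place of hydrogen on the amide-type nitrogen gives an at least 10-fold lower number from compound 2 to compound 3 (1.03 log units; beyond the scatter), the first sign that a change at this nitrogen can move the read-out. Compound 3, at 9130 nM, is the first compound shown with a real number rather than a limit of the assay. The true size of the step remains unknown, because compound 2 has no number of its own: the limit of > 100000 nM in this assay, at which 2 of the 3 values shown sit.

The compounds shown do not tell whether phenyl is special at this nitrogen or whether a smaller methyl, a longer butyl chain or a benzyl group would serve as well. Going by these compounds, it also remains open whether the same phenyl on the core of compound 1 would bring that compound within measurable range.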